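Aryl swap on the shared core, compound 2 to compound 4

The source may hold more compounds than are shown below. What is called first, only, known or untested is meant among the compounds shown, and "the series" means these compounds.

Compound 2 `Nc1nc(NCCNc2ncc(-c3ncc[nH]3)c(-c3ccccc3Br)n2)ccc1[N+](=O)[O-]` stands only at a limit in an ADME assay on microsomes from liver (Rattus norvegicus) for metabolic stability; a lower number here means that the compound disappears faster, a higher number that the compound lasts longer: compound 2 gives > 0.5 h, which is a limit of the assay and not a number. Compound 1 `Nc1nc(NCCNc2ncc(-c3ncc[nH]3)c(-c3ccc(C(F)(F)F)cc3)n2)ccc1[N+](=O)[O-]` likewise gives > 0.5 h, a limit. Compound 3 `Nc1nc(NCCNc2ncc(-c3ncc[nH]3)c(-c3cc(F)c(F)cc3F)n2)ccc1[N+](=O)[O-]` gives > 0.5 h, also a limit. The steps a step that the two limits leave unreadable from compound 1 to compound 2, a step that the two limits leave unreadable from compound 1 to compound 3 and a step that the two limits leave unreadable from compound 2 to compound 3 therefore carry no readable size, since all three values sit at the limit of > 0.5 h in this assay, at which 3 of the 3 values shown sit. Compound 4 `Nc1nc(NCCNc2ncc(-c3ncc[nH]3)c(-c3ccc(Br)cc3Cl)n2)ccc1[N+](=O)[O-]` differs from compound 2 by 4-bromo-2-chlorophenyl in place of 2-bromophenyl on an aromatic carbon. Among the compounds with values here, no measured step bears on this change with a readable size, so no shift beyond the scatter is expected in either direction; the expected step is a step that the limit leaves unreadable from compound 2 to compound 4. Compound 4 is estimated at 1 h, between 0.4 h and 3 h.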

Compound 4, half-life: > 0.5 h
Compound 4 ended at the assay's limit (the forecaster's own chance of this, stated with the estimate: 75%); the middle value lies beyond the limit too.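

The steps from compound 1, compound 2 and compound 3 to compound 4 cannot be read in this assay, and neither can any other step among these compounds: the limit of > 0.5 h in this assay, at which 4 of the 4 values shown sit.

On these data alone, whether the aryl swaps on the shared core change the half-life at all, and how these four compounds rank, stays open.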